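The source may hold more compounds than are shown below. What is called first, only, known or untested is meant among the compounds shown, and "the series" means these compounds.

Measured compounds:
compound 1 `COc1cc(-c2cc(/C=C/C(=O)c3ccc(Cl)c(Cl)c3)[nH]n2)cc(OC)c1OC`: > 100000 nM
compound 2 `COc1ccc(-c2cc(/C=C/C(=O)c3ccc(N)cc3)[nH]n2)cc1OC`: > 100000 nM

In a functional assay on RPMI-8226 cells (Homo sapiens) for inhibition, read by sulforhodamine B assay, with a stated time of 48 h (a lower number here means that less compound is tolerated, a higher number that more compound is tolerated), compound 1 reaches only the limit of the assay and gives > 100000 nM, which is not a number but the ceiling of what was tested. Compound 2 likewise sits at the limit, giving > 100000 nM in this assay. Both values shown therefore lie at the same ceiling, as stated by the limit of > 100000 nM in this assay, at which 2 of the 2 values shown sit, so compound 1 stands nowhere on a scale: it is simply among the compounds for which no lethal concentration was reached within the tested range.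

Compound 3 `COc1ccc(C(=O)/C=C/c2cc(-c3cc(OC)c(OC)c(OC)c3)n[nH]2)cc1OC` has not yet been measured. It differs from compound 1 in one place: 3,4-dimethoxyphenyl in place of 3,4-dichlorophenyl on a carbonyl carbon. Going by the values given here, with both measured compounds at the limit, and no step between measured compounds to guide the size of the change, there is no ground to expect compound 3 to move beyond the scatter in this assay; the step that the limit leaves unreadable from compound 1 to compound 3 is estimated to be none beyond the usual variation. The account therefore expects compound 3 to return 150000 nM, within a range of 50000 nM to 500000 nM, most likely reported again only as a limit.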

Compound 3, concentration lethal to 50% of the cells: > 100000 nM
Compound 3 was reported as a limit; the forecaster's own chance of this, stated with the estimate: 80%; the middle value lies beyond the limit too.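

In this assay compound 3 gives > 100000 nM as a limit of the assay, not a number. Going by these compounds alone, compound 1 also stands at a limit, so no step from compound 1 to compound 3 can be read: the limit of > 100000 nM in this assay, at which 3 of the 3 values shown sit.

The compounds shown leave open at what concentration, if any, each would reach the read-out in this assay and whether 3,4-dimethoxyphenyl in place of 3,4-dichlorophenyl changes it.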